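The compounds below may be only part of what the source reports. "The series", "measured", "known", "first", "only" and "open" are said of these compounds alone.

Measured compounds:
compound 1 `COc1cc(CN(C)C(=O)c2c(OCCCC3CCN(C(=O)OC(C)(C)C)CC3)c3ccccc3n(C)c2=O)cc(OC)c1` — 19000 nM
compound 2 `CCCOc1c(C(=O)N(C)Cc2cc(C(F)(F)F)cc(C(F)(F)F)c2)c(=O)n(C)c2ccccc12` — > 100000 nM

Going by the values given here, in an ADME assay for inhibition of phosphatidylcholine:ceramide cholinephosphotransferase 1 (Homo sapiens), read by mass spectrometry, with stated times of 60 min and 30 min (a lower number here means a stronger inhibitor, a higher number a weaker inhibitor), compound 1 gives 19000 nM, the only number in this set. Compound 2 reaches only a limit of this assay, > 100000 nM, and so yields no number; this is the limit noted as the limit of > 100000 nM in this assay, at which 1 of the 2 values shown sits. Compound 3 `CCOc1cc(CN(C)C(=O)c2c(OCCCC3CCN(C(=O)OC(C)(C)C)CC3)c3ccccc3n(C)c2=O)cc(OCC)c1` differs from compound 1 by 3,5-diethoxyphenyl in place of 3,5-dimethoxyphenyl on a saturated chain carbon bound to an amide-type nitrogen. Among the compounds with values here, no measured pair shows such a step, so its size is open; a change of this kind is expected to stay within the usual scatter. Compound 3 is therefore estimated at 15000 nM, between 6000 nM and 45000 nM, which would be a step of a 1.3-fold lower number from compound 1 to compound 3 (0.10 log units; within the scatter).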

Compound 3, half-maximal inhibitory concentration in the phosphatidylcholine:ceramide cholinephosphotransferase 1 assay: 15000 nM
Compound 3: the middle estimate sits on the measured number at the digits printed; the range from low to high includes it.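

In the phosphatidylcholine:ceramide cholinephosphotransferase 1 assay, 3,5-diethoxyphenyl in place of 3,5-dimethoxyphenyl on a saturated chain carbon bound to an amide-type nitrogen gives a 1.3-fold lower number from compound 1 to compound 3 (0.10 log units; within the scatter), so this position takes the added carbons with no change that stands out from the scatter. In a physicochemical assay for solubility, read by LC-MS, at pH 6.8 (a lower number here means a less soluble compound, a higher number a more soluble compound), the same change gives an at least 22-fold lower number from compound 1 to compound 3 (1.35 log units; beyond the scatter). In the physicochemical assay, compound 1 gives 1.8 ug/mL. In the physicochemical assay, compound 3 reaches only a limit, < 0.08 ug/mL, and not a number.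

The compounds shown leave open how an amine or a carboxylic acid on this phenyl ring would read in either assay. They also leave open what a longer alkoxy chain would do.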